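The source may hold more compounds than are shown below. What is called first, only, known or untested is meant among the compounds shown, and "the series" means these compounds.

Measured in a functional assay on MCF7 cells (Homo sapiens) for cytotoxicity, read by MTT assay, with a stated time of 72 h; on this read-out lower numbers stand for stronger inhibition and higher numbers for weaker inhibition:
compound 1 `COc1cc2ncnc(NNC(=S)NC(=O)c3ccc(C)cc3)c2cc1OC` gives 22300 nM
compound 2 `COc1cc2ncnc(NNC(=S)NC(=O)c3ccc(C(F)(F)F)cc3)c2cc1OC` gives 16800 nM
compound 3 `O=C(NC(=S)NNc1ncnc2ccccc12)c1ccc(C(F)(F)F)cc1` gives 8050 nM

Compounds 1 and 2 share one core; the difference between that core and the core of compound 3 is not broken down here. Compound 3 carries the lowest of the three numbers, and its steps to compound 2 and to compound 1 are both beyond the scatter. Going by the values given here, the single counted change, (methyl in place of trifluoromethyl on an aromatic carbon), gives a 1.3-fold higher number from compound 2 to compound 1 (0.12 log units; within the scatter). Compound 4 `Cc1ccc(C(=O)NC(=S)NNc2ncnc3ccccc23)cc1` applies this change to the core of compound 3: methyl in place of trifluoromethyl on an aromatic carbon. The place is described in the same words in both cases, so this is the same change on a different core. Resting on a 1.3-fold higher number from compound 2 to compound 1 (0.12 log units; within the scatter), the step expected from compound 3 to compound 4 is a 1.2-fold higher number from compound 3 to compound 4 (0.09 log units; within the scatter), with one prior case carrying limited weight. For compound 4 the expected value in this assay is 10000 nM, between 5000 nM and 20000 nM.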

Compound 4, half-maximal inhibitory concentration: 7820 nM
Estimate against measurement, compound 4: 1.3-fold (0.11 log units) above; the measured number falls inside the stated range.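

In this assay, methyl in place of trifluoromethyl gives a 1.0-fold lower number from compound 3 to compound 4 (0.01 log units; within the scatter), so on this core too the change produces no step beyond the scatter. Set beside the earlier case, the two steps do not differ: the same change on two cores in this assay, a 1.3-fold higher number (0.12 log units; within the scatter) from compound 2 to compound 1 and a 1.0-fold lower number (0.01 log units; within the scatter) from compound 3 to compound 4, 1.4-fold (0.14 log units) apart, within the scatter of two such steps. This shows that, for this one exchange at this one place, the near-absence of a step carries from one core to the other; it does not show that a change with a step beyond the scatter would carry in the same way, and two cases set no rule for the series.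

Still open, as far as these compounds go, is whether an amine, a carboxylic acid or a longer chain at this place, on an aromatic carbon para to a large group, would move the number beyond the scatter on either core. Also open, from the compounds shown here alone, is whether such groups would behave alike on the two cores.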